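Replacing the pyridinyl-piperazine with tetrahydroquinoline: solubility outlook

The source may report more compounds than this note shows. Statements on the series, on what has been measured and on what is new or still open speak of the compounds shown alone.

Three compounds sharing one core have been run in a physicochemical assay for solubility, read by spectrophotometry, in phosphate buffer, with a stated time of 2 h, at pH 7.4; on this read-out lower numbers stand for lower solubility and higher numbers for higher solubility. Compound 3 `COc1ccc2[nH]c(C(=O)N3CC(=O)N(Cc4ccccc4)[C@@H](CN4CCN(c5ccccn5)CC4)C3)cc2c1` is the only one of them that gives an actual number: in this assay compound 3 gives 30200 nM. For compound 1 `COc1ccc2[nH]c(C(=O)N3CC(=O)N(Cc4ccccc4)[C@@H](CN4CCCCC4)C3)cc2c1` this assay reports only a limit, > 25000 nM. For compound 2 `COc1ccc2[nH]c(C(=O)N3CC(=O)N(Cc4ccccc4)[C@@H](Cc4ccccn4)C3)cc2c1` it likewise reports only a limit, > 100000 nM.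

Of the measured steps, only one can be read: an at least 3.3-fold lower number from compound 2 to compound 3 (0.51 log units; beyond the scatter), which went with 4-(pyridin-2-yl)piperazin-1-yl in place of pyridin-2-yl on a saturated chain carbon bound to a saturated ring carbon. The steps a step that the two limits leave unreadable from compound 1 to compound 2 and a step that the limit leaves unreadable from compound 1 to compound 3 cannot be sized because of the limit of > 25000 nM in this assay, at which 1 of the 3 values shown sits, and because of the limit of > 100000 nM in this assay, at which 1 of the 3 values shown sits.

Compound 4 `COc1ccc2[nH]c(C(=O)N3CC(=O)N(Cc4ccccc4)[C@@H](CN4CCCc5ccccc54)C3)cc2c1` differs from compound 3 by 1,2,3,4-tetrahydroquinolin-1-yl in place of 4-(pyridin-2-yl)piperazin-1-yl on a saturated chain carbon bound to a saturated ring carbon. Among the measured compounds shown here, no measured step exchanges these two groups, so the single readable step gives only a loose guide; the replacement of a larger, nitrogen-rich group by a smaller one with fewer acceptors is expected to lower the solubility somewhat, though the size is uncertain. Compound 4 is therefore estimated to give 10000 nM, expected to lie between 3000 nM and 35000 nM. That corresponds to an expected step of a 3.0-fold lower number from compound 3 to compound 4 (0.48 log units; beyond the scatter).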

Compound 4, solubility: 8500 nM
Estimate against measurement, compound 4: 1.2-fold (0.07 log units) above, and the stated range covers the measured number.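

In this assay, among the compounds shown here, the change from 4-(pyridin-2-yl)piperazin-1-yl to 1,2,3,4-tetrahydroquinolin-1-yl gives a 3.6-fold lower number from compound 3 to compound 4 (0.55 log units; beyond the scatter), the first step at this place, on a saturated chain carbon bound to a saturated ring carbon, with an actual number at both ends. Compound 4 also has the lowest number of the four, as the other two new steps show: an at least 11-fold lower number from compound 2 to compound 4 (1.07 log units; beyond the scatter) and an at least 2.9-fold lower number from compound 1 to compound 4 (0.46 log units; beyond the scatter). Each of these two steps starts from a limit, so it gives a minimum size and not an exact one.

The exchange changes both rings and the count of nitrogen atoms together, so the compounds shown leave open which of these differences goes with the lower number. A morpholin-4-yl group or a 1,2,3,4-tetrahydroisoquinolin-2-yl group at the same place would help separate them, while a carboxylic acid added to the tetrahydroquinoline would test whether the number can be raised again without giving up that ring.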